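The source may hold more compounds than are shown below. What is called first, only, known or untested is meant among the compounds shown, and "the series" means these compounds.

Working notes on the series. The shared core carries, on a saturated chain carbon, a varying five-membered group. In a physicochemical assay for solubility, measured as kinetic solubility, at pH 2 (on this read-out lower numbers stand for lower solubility and higher numbers for higher solubility), compound 1 `CC(C)/C(=C1\C(=O)NC(=O)N1C)c1ccc(-c2ccc3cccc(F)c3c2)[nH]c1=O` gives 11100 nM, compound 2 `CC(C)C(c1ccc(-c2ccc3cccc(F)c3c2)[nH]c1=O)C1SC(=O)NC1=O` gives 11300 nM and compound 3 `O=C1NC(=O)/C(=C/C2(c3ccc(-c4ccc5cccc(F)c5c4)[nH]c3=O)CC2)O1` gives 27400 nM. Compound 2 thus stands level with compound 1 within the usual scatter, while compound 3 lies higher by more than the scatter.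

Compound 4 `CC(C)C(c1ccc(-c2ccc3cccc(F)c3c2)[nH]c1=O)C1NC(=O)NC1=O` has not been measured in this assay. Relative to compound 2 the change is 2,5-dioxoimidazolidin-4-yl in place of 2,4-dioxo-1,3-thiazolidin-5-yl on a saturated chain carbon bound to an aromatic carbon and a saturated chain carbon. For the measured compounds named here, no measured pair in the set isolates this exchange, so no step is known for it. The step from compound 2 to compound 4 is expected to be small, a 1.2-fold higher number from compound 2 to compound 4 (0.09 log units; within the scatter), tending upward if anything but not clearly beyond the scatter. Compound 4 is therefore estimated at 14000 nM, with a range from 7000 nM to 30000 nM.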

Compound 4, solubility: 5800 nM
For compound 4 the middle estimate is 2.4-fold (0.38 log units) above the measured one; the measured number lies below the stated range.
By their numbers in this assay, from the lowest: compounds 4, 1 and 2 (each within the scatter of the next); then compound 3.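

In this assay, for the compounds shown here, 2,5-dioxoimidazolidin-4-yl in place of 2,4-dioxo-1,3-thiazolidin-5-yl on a saturated chain carbon bound to an aromatic carbon and a saturated chain carbon gives a 1.9-fold lower number from compound 2 to compound 4 (0.29 log units; within the scatter), the first exchange at this position that can be read in one place. This exchange of one five-membered ring for another therefore stays within the scatter. No available measurement bears on the reason for this result. The compounds shown leave open whether an amine or a carboxylic acid in place of the five-membered ring at this position would give a step beyond the scatter. Steps to compound 1 and compound 3 cannot be read.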